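The source may hold more compounds than are shown below. What is called first, only, known or untested is meant among the compounds shown, and "the series" means these compounds.

Measured in a physicochemical assay for lipophilicity, measured as octanol-water partition; a lower number here means a more polar compound, a higher number a more lipophilic compound:
compound 1 `O=C(COc1cccc2ccccc12)N/N=C/c1cccc(O)c1`: 3.73
compound 2 `COc1ccc(/C=N/NC(=O)COc2cccc3ccccc23)cc1O`: 3.48

Among the compounds with values here, compound 1 and compound 2 lie within the scatter of each other; the only step between them is a number 0.25 log units lower from compound 1 to compound 2 (within the scatter), methoxy in place of hydrogen on an aromatic carbon. Compound 3 `O=C(COc1cccc2ccccc12)N/N=C/c1cccc([N+](=O)[O-])c1` is not yet measured. It differs from compound 1 by nitro in place of hydroxy on an aromatic carbon, meta to a large group. Within the data shown here, no measured step covers this exchange, so nothing bears on it directly. For compound 3 the estimate starts from compound 1 at 3.73. The step expected in this assay is a number 0.37 log units higher from compound 1 to compound 3 (beyond the scatter), a rise somewhat beyond the scatter. Compound 3 is thus estimated at 4.1, range 3.7 to 4.5.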

Compound 3, partition coefficient: 3.97
Beside the measured number, compound 3's estimate is 0.13 log units above it; the range from low to high includes it.
By their numbers in this assay, from the lowest: compounds 2, 1 and 3 (each within the scatter of the next, the first and the last beyond it).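

In this assay, nitro in place of hydroxy on an aromatic carbon, meta to a large group, gives a number 0.24 log units higher from compound 1 to compound 3 (within the scatter). Within the data shown here, this is the first exchange read at this position, and replacing hydroxy, with 1 hydrogen-bond donor, by nitro, with 0 hydrogen-bond donors and 3 heavy atoms, leaves the read-out within the scatter. Nothing at hand explains this result.

On these data alone, whether an amine or a carboxylic acid on this carbon would also stay within the scatter of compound 1 remains open. Also open, as far as these compounds go, is whether the same exchange reads alike with the methoxy of compound 2 in place.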